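This account rests on a few compounds, and the source may have more. Where it says the series, first, only, none or still open, it means among the compounds named here.

Measured so far: compound 2 `CCN1CCN(c2cc(C)c3cc(NC(=O)c4ccccc4C)ccc3n2)CC1` gives 10900 nM; compound 1 `CCN1CCN(c2cc(C)c3cc(NC(=O)c4ccccc4F)ccc3n2)CC1` gives 32600 nM; compound 3 `CCc1ccc(C(=O)Nc2ccc3nc(N4CCN(CC)CC4)cc(C)c3c2)cc1` gives 3060 nM, all in a functional assay on MCF7 cells (Homo sapiens) for antiproliferative activity, read by MTT assay, with a stated time of 72 h; on this read-out higher numbers stand for weaker inhibition and lower numbers for stronger inhibition.

Among these three numbers, compound 2 stands second highest: a 3.0-fold lower number from compound 1 to compound 2 (0.48 log units; beyond the scatter), and a 3.6-fold lower number from compound 2 to compound 3 (0.55 log units; beyond the scatter). Compound 4 `CCN1CCN(c2cc(C)c3cc(NC(=O)c4ccc(Br)cc4)ccc3n2)CC1` differs from compound 2 in one place: 4-bromophenyl in place of 2-methylphenyl on a carbonyl carbon. For the measured compounds named here, two measured steps bear on this change. Replacing 2-methylphenyl with 4-ethylphenyl gave a 3.6-fold lower number from compound 2 to compound 3 (0.55 log units; beyond the scatter), and replacing 2-fluorophenyl with 4-ethylphenyl gave an 11-fold lower number from compound 1 to compound 3 (1.03 log units; beyond the scatter). Both point the same way, so a step of similar size toward a lower number in this assay is expected, though 4-bromophenyl is not the same group as 4-ethylphenyl. Compound 4 is therefore estimated at 3500 nM, between 1200 nM and 10000 nM, which is expected to mean a 3.1-fold lower number from compound 2 to compound 4 (0.49 log units; beyond the scatter).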

Compound 4, half-maximal inhibitory concentration: 5940 nM
Compound 4: the middle estimate sits 1.7-fold (0.23 log units) below what was measured, and the stated range covers the measured number.
By their numbers in this assay, from the lowest: compounds 3, 4 and 2 (each within the scatter of the next, the first and the last beyond it); then compound 1.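

At this carbonyl carbon, 4-bromophenyl does not separate from 2-methylphenyl (a 1.8-fold lower number from compound 2 to compound 4 (0.26 log units; within the scatter)), and bromo does not separate from ethyl on the aromatic carbon (a 1.9-fold higher number from compound 3 to compound 4 (0.29 log units; within the scatter)). Only against the 2-fluorophenyl group does the change stand clear of the scatter (a 5.5-fold lower number from compound 1 to compound 4 (0.74 log units; beyond the scatter)). No measurement given here explains these results.

As far as these compounds go, it remains open whether an amine or a carboxylic acid in place of the bromo would give a number in the same range. The compounds also leave open how 2-bromophenyl would compare with 4-bromophenyl.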